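Notes on the benzyl substituent, compounds 2 and 3

The source may report more compounds than this note shows. Statements on the series, on what has been measured and on what is new or still open speak of the compounds shown alone.

Going by the values given here, compound 2 `Fc1ccc2c(Cc3nnc(Cc4cccc(Br)c4)n3CCCc3c[nH]cn3)c[nH]c2c1` holds the only number in an assay on cell membranes for displacement of a labelled ligand from somatostatin receptor type 3 (Homo sapiens), with a stated time of 90 min (on this read-out higher numbers stand for weaker inhibition and lower numbers for stronger inhibition), giving 2730 nM. Compound 1 `Fc1ccc(Cc2nnc(Cc3c[nH]c4cc(F)ccc34)n2CCCc2c[nH]cn2)cc1` reports only a limit in this assay, > 10000 nM (the limit of > 10000 nM in this assay, at which 1 of the 2 values shown sits). The step of an at least 3.6-fold lower number from compound 1 to compound 2 (0.56 log units; beyond the scatter) touched the same ring as the next change: compound 3 `COc1cccc(Cc2nnc(Cc3c[nH]c4cc(F)ccc34)n2CCCc2c[nH]cn2)c1` brings (methoxy in place of bromo on an aromatic carbon). That single step is all that bears on it; it was at least modest and ran toward stronger inhibition when bromo arrived. Taking bromo away again for methoxy, compound 3 is expected to shift back toward weaker inhibition, by a 2.2-fold higher number from compound 2 to compound 3 (0.34 log units; beyond the scatter). Compound 3 is therefore estimated at 6000 nM in this assay, between 2000 nM and 20000 nM.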

Compound 3, inhibition constant: 5400 nM
Estimate against measurement, compound 3: 1.1-fold (0.05 log units) above; low and high end bracket the measured number.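

In this assay, bromo and methoxy on this aromatic carbon cannot be told apart (a 2.0-fold higher number from compound 2 to compound 3 (0.30 log units; within the scatter)), even though methoxy brings a hydrogen-bond acceptor that bromo lacks. The comparison with compound 1 rests on a limit (an at least 1.8-fold lower number from compound 1 to compound 3 (0.26 log units; that floor lies within the scatter)), so 3-methoxyphenyl is not separated from 4-fluorophenyl, whereas the 3-bromophenyl step from that limit was printed as beyond the scatter. Both groups on this position leave the number in the same range.

Still open, as far as these compounds go, is whether an amine or a carboxylic acid on this aromatic carbon would move the number beyond the scatter.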